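Replacing the Dichlorobenzyl Group in a Weak Antiproliferative Series

The compounds below may be only part of what the source reports. "The series", "measured", "known", "first", "only" and "open" are said of these compounds alone.

Of the compounds shown here, three sharing one core have been measured in a functional assay on MKN-74 cells (Homo sapiens) for antiproliferative activity, with a stated time of 24 h; on this read-out higher numbers stand for weaker inhibition and lower numbers for stronger inhibition. Compound 1 `NC(=O)c1c(NC(=O)c2ccccc2Cl)sc2c1CCN(Cc1cc(Cl)cc(Cl)c1)C2` gives 23700 nM in this assay. Compound 2 `Cc1ccc(C(=O)Nc2sc3c(c2C(N)=O)CCN(Cc2c(Cl)cccc2Cl)C3)cc1` gives 12300 nM, and compound 3 `Cc1ccc(C(=O)Nc2sc3c(c2C(N)=O)CCN(Cc2ccc(Cl)cc2Cl)C3)cc1` gives 25500 nM. Compound 1 thus sits with the second highest of the three numbers, close to compound 3 and within the scatter of both other compounds. For the measured compounds named here, the only single-point step available, a 2.1-fold higher number from compound 2 to compound 3 (0.32 log units; beyond the scatter), moves the chlorine pattern around the benzyl ring and produces a modest change.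

Compound 4 `COc1ccc(NC(=S)N2CCc3c(sc(NC(=O)c4ccccc4Cl)c3C(N)=O)C2)cc1` differs from compound 1 in this way: a group of 11 heavy atoms (8 carbon, 1 nitrogen, 1 oxygen, 1 sulfur; one six-membered aromatic ring of carbon only) in place of a group of 9 heavy atoms (7 carbon, 2 chlorine; one six-membered aromatic ring of carbon only), on an amine nitrogen in a ring. The incoming group carries a hydrogen-bond donor and acceptors that the outgoing one lacks, and it is attached through a double bond outside aromatic rings rather than a saturated chain carbon. Going by the values given here, no measured step tests such a replacement; the step from compound 2 to compound 3 only reshuffles chlorines on a benzyl group that is removed entirely here, so it bears on compound 4 only weakly. With every measured number already weak, compound 4 is expected to remain in the same region, and a step of a 1.2-fold lower number from compound 1 to compound 4 (0.07 log units; within the scatter) of no clear direction is estimated. Compound 4 is expected to give 20000 nM, with a range from 5000 nM to 80000 nM.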

Compound 4, half-maximal inhibitory concentration: 19600 nM
Beside the measured number, compound 4's estimate is 1.0-fold (0.01 log units) above it, and the stated range covers the measured number.
By their numbers in this assay, from the lowest: compounds 2, 4, 1 and 3 (each within the scatter of the next, the first and the last beyond it).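

In this assay, putting the group with no common name in place of 3,5-dichlorobenzyl on the amine nitrogen in a ring gives a 1.2-fold lower number from compound 1 to compound 4 (0.08 log units; within the scatter), so the two numbers cannot be told apart. The earlier compounds shown here varied only the chlorines on a benzyl group, whereas here the benzyl group is gone altogether, and the entering group brings a hydrogen-bond donor, hydrogen-bond acceptors and a double bond outside aromatic rings, with the result still in the same weak region. Nothing measured here explains why such different groups give numbers this alike.

Open, on these data alone, is whether any group on this nitrogen can move the number far from this region, such as a plain methyl or a short chain ending in a carboxylic acid. Also open, as far as these compounds go, is what the sulfur of the entering group contributes, which a version carrying oxygen in its place would test.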